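The compounds below may be only part of what the source reports. "The series", "measured", "known", "first", "only" and "open" are said of these compounds alone.

Of the compounds shown here, three have been measured so far in a functional assay on VCaP cells (Homo sapiens) for antiproliferative activity, read by propidium iodide staining, with a stated time of 96 h (on this read-out lower numbers stand for stronger inhibition and higher numbers for weaker inhibition), and a fourth awaits its number. Compound 1 `CC(O)(COc1ccc(S(F)(F)(F)(F)F)cc1)C(=O)Nc1ccc(C#N)c(C(F)(F)F)c1` gives 30100 nM in this assay. Compound 2 `CC(O)(COc1ccc(S(F)(F)(F)(F)F)cc1)C(=O)Nc1ccc([N+](=O)[O-])c(C(F)(F)F)c1` gives 100000 nM. The two differ in one place, (nitro in place of cyano on an aromatic carbon), and that change made a step of a 3.3-fold higher number from compound 1 to compound 2 (0.52 log units; beyond the scatter). Compound 3 `CC(O)(COc1cccc(S(F)(F)(F)(F)F)c1)C(=O)Nc1ccc(C#N)cc1C(F)(F)F` gives 10300 nM, the lowest of the three numbers; the difference between its core and the core of compound 1 is not broken down here.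

Compound 4 `CC(O)(COc1cccc(S(F)(F)(F)(F)F)c1)C(=O)Nc1ccc([N+](=O)[O-])cc1C(F)(F)F` has not yet been measured. It differs from compound 3 in one place, (nitro in place of cyano on an aromatic carbon). Among the measured compounds shown here, this is the same kind of change as the one from compound 1 to compound 2, though the surroundings are not identical: in compound 2 the nitro sits ortho to a trifluoromethyl group, while in compound 4 it sits meta to a trifluoromethyl group, in each case para to a large group. With a single prior example, the expectation for compound 4 is modest in confidence. A step of about a 3.1-fold higher number from compound 3 to compound 4 (0.49 log units; beyond the scatter) is expected from compound 3 to compound 4 in this assay, because the like change gave a 3.3-fold higher number from compound 1 to compound 2 (0.52 log units; beyond the scatter). The number for compound 4 is therefore estimated at 32000 nM, with a likely range from 12000 nM to 100000 nM.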

Compound 4, half-maximal inhibitory concentration: 20300 nM
Beside the measured number, compound 4's estimate is 1.6-fold (0.20 log units) above it; low and high end bracket the measured number.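

In this assay, putting nitro in place of cyano on the core of compound 3 gives a 2.0-fold higher number from compound 3 to compound 4 (0.29 log units; within the scatter), so on this core the effect of the swap cannot be told apart from the ordinary spread of repeated measurements. Among the compounds shown here, only two pairs of compounds carry this change, and that is too few to make a rule for the series. These numbers do not show what sets the size of either step. What they do show is that the step seen on the first core is compatible with the one seen on the second, so the change can be said to carry over only in this limited sense, with the two steps no further apart than repeat measurements would allow: the same change on two cores in this assay, a 3.3-fold higher number (0.52 log units; beyond the scatter) from compound 1 to compound 2 and a 2.0-fold higher number (0.29 log units; within the scatter) from compound 3 to compound 4, 1.7-fold (0.23 log units) apart, within the scatter of two such steps.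

The compounds shown leave open what other groups on this aromatic carbon, such as an amine or a carboxylic acid, would do to the number in place of cyano or nitro. Also open, from the compounds shown here alone, is whether the same swap would give a similar step on a third core, and how much of the spread among the four numbers comes from the cores alone.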